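The source may report more compounds than this note shows. Statements on the series, on what has been measured and on what is new or still open speak of the compounds shown alone.

Measured so far:

Compound 1, `Oc1ccc(-c2cc(-c3ccsc3)cc(-c3ccccc3O)n2)cc1`: in a functional assay on DU-145 cells (Homo sapiens) for cytotoxicity, read by CCK-8 assay (on this read-out higher numbers stand for weaker inhibition and lower numbers for stronger inhibition), compound 1 gives > 50000 nM, which is a limit of the assay and not a number.
Compound 2, `Oc1ccc(-c2cc(-c3ccsc3)cc(-c3cccc(O)c3)n2)cc1`: compound 2 gives 2230 nM.
Compound 3, `Oc1cccc(-c2cc(-c3ccoc3)cc(-c3ccccc3O)n2)c1`: compound 3 gives 2790 nM.

Among the measured compounds shown here, the one step that is measured is 3-hydroxyphenyl in place of 2-hydroxyphenyl on an aromatic carbon, and it made an at least 22-fold lower number from compound 1 to compound 2 (1.35 log units; beyond the scatter). Its true size is open, since compound 1 sits at the limit of > 50000 nM in this assay, at which 1 of the 3 values shown sits.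

Compound 4, `Oc1cccc(-c2cc(-c3ccoc3)cc(-c3cccc(O)c3)n2)c1`, has not been measured. It differs from compound 3 by 3-hydroxyphenyl in place of 2-hydroxyphenyl on an aromatic carbon. For the measured compounds named here, this is the same kind of change as the one from compound 1 to compound 2, not the same change: there the place was meta to a 4-hydroxyphenyl group and meta to a thiophen-3-yl group, here it is meta to a 3-hydroxyphenyl group and meta to a furan-3-yl group. How the core of compound 3 differs from that of compound 1 is not broken down here.

On these data alone, from compound 3 to compound 4 a step of about a 4.7-fold lower number from compound 3 to compound 4 (0.67 log units; beyond the scatter) is expected, smaller than an at least 22-fold lower number from compound 1 to compound 2 (1.35 log units; beyond the scatter), since that step started from a limit and its full size is unknown. Compound 4 is therefore estimated at 600 nM, with a range from 150 nM to 2500 nM.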

Compound 4, half-maximal inhibitory concentration: 1650 nM
Compound 4: middle estimate off by 2.8-fold (0.44 log units), on the low side, within the range that was stated.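

In this assay, the change from 2-hydroxyphenyl to 3-hydroxyphenyl does not keep its size when carried from one core to the other: the same change on two cores in this assay, an at least 22-fold lower number (1.35 log units; beyond the scatter) from compound 1 to compound 2 and a 1.7-fold lower number (0.23 log units; within the scatter) from compound 3 to compound 4, at least 13-fold (1.12 log units) apart, beyond the scatter of two such steps. On the second core the change gives a 1.7-fold lower number from compound 3 to compound 4 (0.23 log units; within the scatter), so there its effect cannot be told apart from the variation between repeated measurements, and a large step on one core is no safe guide to the step on another. On these data alone, what this does not show is which difference between the two cores matters, and the true size of the first step also stays unknown, as compound 1 gives a limit of the assay and not a number: the limit of > 50000 nM in this assay, at which 1 of the 4 values shown sits.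

As far as these compounds go, whether the change is large or small on any further core remains open. Also open, from the compounds shown here alone, is how this assay would respond if an amine or a carboxylic acid took the place of the hydroxyl group on these phenyl rings.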